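Removing a Methyl from the Ester Cap

This account rests on a few compounds, and the source may have more. Where it says the series, first, only, none or still open, it means among the compounds named here.

Compound 1 `CC1=CC[C@]2(C)[C@@H]([C@@H](OC(=O)c3ccc(O)cc3)C1)[C@](O)(C(C)C)C[C@@H]2O` and compound 2 `COc1ccc(C(=O)O[C@H]2CC(C)=CC[C@@]3(C)CC[C@@](O)(C(C)C)[C@H]23)cc1` share a core and carry an aromatic ester cap, differing in that cap and in the hydroxyls on the core. In a functional assay on RS4-11 cells (Homo sapiens) for cytotoxicity, read by MTT assay, with a stated time of 72 h (a higher number here means a weaker inhibitor, a lower number a stronger inhibitor), compound 1 gives 33400 nM, and compound 2 gives 17600 nM. Compound 2 holds the lower of the two numbers, but its gap to compound 1 lies within the scatter, so neither compound can be called the stronger inhibitor. Compound 3 `CC1=CC[C@@]2(C)CC[C@@](O)(C(C)C)[C@@H]2[C@@H](OC(=O)c2ccc(O)cc2)C1` has not yet been measured. It differs from compound 2 by one change: hydrogen in place of methyl on an oxygen on an aromatic ring. Going by the values given here, no measured pair isolates this change alone, so the expectation rests on compound 1, which carries the same 4-hydroxyphenyl ester and gives 33400 nM in this assay. The step of a 1.4-fold higher number from compound 2 to compound 3 (0.15 log units; within the scatter) is expected to stay within the scatter, leaning if anything toward a weaker inhibitor. Compound 3 is estimated to give 25000 nM, with a range from 10000 nM to 60000 nM.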

Compound 3, half-maximal inhibitory concentration: > 100000 nM
Compound 3 was reported as a limit; the forecaster's own chance of this, stated with the estimate: 10%; at least 4.0-fold (0.60 log units) between middle value and limit.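

In this assay compound 3 gives > 100000 nM, which is a limit of the assay and not a number. Hydrogen in place of methyl on an oxygen on an aromatic ring gives an at least 5.6-fold higher number from compound 2 to compound 3 (0.75 log units; beyond the scatter), so this one-carbon change on the ester cap, which could not be isolated before, leaves a clearly weaker inhibitor. Hydrogen in place of hydroxy on a saturated ring carbon gives an at least 2.9-fold higher number from compound 1 to compound 3 (0.47 log units; beyond the scatter), which shows that with the 4-hydroxyphenyl ester in place, that hydroxy on the core also counts.

As far as these compounds go, what a longer chain on the cap oxygen, such as an ethoxy group, or an amine in place of that oxygen would do remains open. Also open, from the compounds shown here alone, is why these two changes weaken the compounds, and whether the core hydroxy counts in the same way alongside the 4-methoxyphenyl ester.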